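The source may report more compounds than this note shows. Statements on the series, on what has been measured and on what is new or still open speak of the compounds shown alone.

Compound 3 `CN(C)c1ccc(/C=N/NC(=O)CSc2nnnn2C)cc1` gives the lowest number of the three measured in an ADME assay on NIH3T3 cells (Mus musculus) for cytotoxicity, read by XTT assay, with a stated time of 24 h (a higher number here means a weaker inhibitor, a lower number a stronger inhibitor), at 316000 nM. Its neighbours are compound 1 `Cn1nnnc1SCC(=O)N/N=C/c1ccccc1`, which in this assay gives 9700000 nM, and compound 2 `Cn1nnnc1SCC(=O)N/N=C/c1ccc([N+](=O)[O-])cc1`, which gives 9300000 nM. The steps to compound 3 were large: a 31-fold lower number from compound 1 to compound 3 (1.49 log units; beyond the scatter) and a 29-fold lower number from compound 2 to compound 3 (1.47 log units; beyond the scatter), whereas a 1.0-fold lower number from compound 1 to compound 2 (0.02 log units; within the scatter). Compound 4 `COc1ccc(/C=N/NC(=O)CSc2nnnn2C)cc1` has not yet been measured; it differs from compound 3 by methoxy in place of dimethylamino on an aromatic carbon. Among the compounds with values here, no measured step puts methoxy at this position, so the only guide is that the dimethylamino step from compound 1, a 31-fold lower number from compound 1 to compound 3 (1.49 log units; beyond the scatter), and from compound 2, a 29-fold lower number from compound 2 to compound 3 (1.47 log units; beyond the scatter), was what set compound 3 apart, while hydrogen and nitro gave numbers within the scatter of each other. Removing the dimethylamino is therefore expected to move compound 4 back toward those higher numbers, most likely part of the way, giving an expected step of a 6.3-fold higher number from compound 3 to compound 4 (0.80 log units; beyond the scatter). Compound 4 is thus estimated at 2000000 nM, with a range from 500000 nM to 8000000 nM.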

Compound 4, half-maximal inhibitory concentration: > 10000000 nM
Compound 4 ended at the assay's limit (the forecaster's own chance of this, stated with the estimate: 10%); at least 5.0-fold (0.69 log units) between middle value and limit.
By their numbers in this assay, from the lowest: compound 3; then compounds 2 and 1 (each within the scatter of the next). At a limit, above all of these: compound 4.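

In this assay, methoxy in place of dimethylamino on this aromatic carbon, para to a large group, does not keep the low number: an at least 31-fold higher number from compound 3 to compound 4 (1.50 log units; beyond the scatter). Compound 4 stands at a limit of the assay, > 10000000 nM, and not at a number. The other two steps are floors within the scatter, an at least 1.0-fold higher number from compound 2 to compound 4 (0.03 log units; that floor lies within the scatter) and an at least 1.0-fold higher number from compound 1 to compound 4 (0.01 log units; that floor lies within the scatter), so no order can be read among these three compounds, and of the four groups at this position only dimethylamino stands apart.

On these data alone, how far the number of compound 4 lies past the limit stays open. Also open, as far as these compounds go, is whether the low number belongs to dimethylamino alone or would also come with another amine at this position, such as a plain amino group or diethylamino.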